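Swapping a Pyrrole for a Furan on a Shared Core

The source may report more compounds than this note shows. Statements on the series, on what has been measured and on what is new or still open speak of the compounds shown alone.

Compound 1, `O=C(O)c1ccc(CN2C(=O)S/C(=C\c3ccccc3)C2=O)cc1`: 88000 nM
Compound 2, `Cn1cccc1/C=C1\SC(=O)N(Cc2ccc(C(=O)O)cc2)C1=O`: 88000 nM

Both compounds were tested in a functional assay on HT-29 cells (Homo sapiens) for cytotoxicity, read by MTT assay, with a stated time of 24 h; on this read-out lower numbers stand for stronger inhibition and higher numbers for weaker inhibition. In this assay compound 1 gives 88000 nM, and compound 2 gives 88000 nM. The step of no change at the digits printed from compound 1 to compound 2 (within the scatter) shows that replacing phenyl with 1-methyl-1H-pyrrol-2-yl left the read-out where it was, so compound 2 stands level with compound 1 at the digits shown.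

Compound 3, `O=C(O)c1ccc(CN2C(=O)S/C(=C\c3ccco3)C2=O)cc1`, has not been measured yet. Its difference from compound 2 is furan-2-yl in place of 1-methyl-1H-pyrrol-2-yl on a double-bonded chain carbon bound to a double-bonded ring carbon. Within the data shown here, this is again a change of the aromatic group at the same place on the shared core, and the only comparable step on record, the one from compound 1 to compound 2, stayed within the scatter. On that basis the step is expected to be no change at the digits printed from compound 2 to compound 3 (within the scatter), with no shift beyond the scatter in either direction. Compound 3 is therefore estimated at 88000 nM, in a range from 40000 nM to 190000 nM.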

Compound 3, half-maximal inhibitory concentration: 94000 nM
For compound 3 the middle estimate is 1.1-fold (0.03 log units) below the measured one; the range from low to high includes it.
By their numbers in this assay, from the lowest: compounds 1, 2 and 3 (each within the scatter of the next).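

Up to this point, the only comparison at this place was phenyl against a ring with a nitrogen. Compound 3 adds a ring whose hetero atom is oxygen, and in this assay furan-2-yl on a double-bonded chain carbon bound to a double-bonded ring carbon gives a 1.1-fold higher number from compound 2 to compound 3 (0.03 log units; within the scatter) and a 1.1-fold higher number from compound 1 to compound 3 (0.03 log units; within the scatter). Both steps lie within the scatter, so this read-out does not separate the three aromatic groups, and no information is available on why they read alike.

From the compounds shown here alone, all three compounds carry an aromatic ring at this place, so it remains open whether something of another kind there, such as an amine or a longer chain, would move the number beyond the scatter. Going by these compounds, it also remains open whether changing the carboxylic acid, which is the same in all three, would alter the read-out.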